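This account rests on a few compounds, and the source may have more. Where it says the series, first, only, none or still open, it means among the compounds named here.

Compound 2 `O=c1[nH]/c(=N\OCCCCc2ccccc2)ccn1[C@@H]1O[C@H](COP(=O)(O)OP(=O)(O)OP(=O)(O)O)[C@@H](O)[C@H]1O` gives 54 nM in a functional assay on 1321-N1 cells for agonist activity at P2Y purinoceptor 4 (Homo sapiens), read by scintillation counting and inositol phosphate accumulation (on this read-out lower numbers stand for an effect already at smaller amounts and higher numbers for an effect only at larger amounts of compound), and stands lowest of the two numbers measured; compound 1 `O=C(O)CCCO/N=c1/ccn([C@@H]2O[C@H](COP(=O)(O)OP(=O)(O)OP(=O)(O)O)[C@@H](O)[C@H]2O)c(=O)[nH]1` gives 470 nM in this assay, and the step of an 8.7-fold lower number from compound 1 to compound 2 (0.94 log units; beyond the scatter) is beyond the scatter. Compound 3 `O=c1[nH]/c(=N\OCCOc2ccccc2)ccn1[C@@H]1O[C@H](COP(=O)(O)OP(=O)(O)OP(=O)(O)O)[C@@H](O)[C@H]1O` differs from compound 2 by phenoxy in place of phenethyl on a saturated chain carbon, two bonds along the chain from an oxygen. Among the compounds with values here, only the step from compound 1 to compound 2 bears on it, and that step changed the group at the chain end, whereas here the aromatic ring is kept and the chain is shortened by one carbon with an oxygen entering. For compound 3 a small step in this assay, a 2.0-fold higher number from compound 2 to compound 3 (0.31 log units; beyond the scatter), is expected, with a value estimated near 110 nM, between 35 nM and 350 nM.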

Compound 3, half-maximal effective concentration: 430 nM
Beside the measured number, compound 3's estimate is 3.9-fold (0.59 log units) below it; the measured number lies above the stated range.
By their numbers in this assay, from the lowest: compound 2; then compounds 3 and 1 (each within the scatter of the next).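

In this assay the step of an 8.0-fold higher number from compound 2 to compound 3 (0.90 log units; beyond the scatter) goes with phenoxy in place of phenethyl, so keeping an aromatic ring at the chain end does not by itself hold the lower number. The step of a 1.1-fold lower number from compound 1 to compound 3 (0.04 log units; within the scatter) goes with phenoxy in place of carboxymethyl, which shows that a ring and a carboxylic acid at this place can give values within the scatter. No evidence at hand accounts for these steps.

On these data alone, whether the oxygen or the shorter chain sets the step stays open, as the two change together in compound 3. A 3-phenylpropyl group in the same place would separate them.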